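The compounds below may be only part of what the source reports. "The series", "measured", "known", "first", "only" and "open" are said of these compounds alone.

Compound 1 `O=C(O)c1ccc(N(C(=O)CCCCCBr)c2ccc(C(=O)O)cc2)cc1` and compound 2 `CCCCCCCCCCOc1cc(OCCCCCCCCCC)cc(OCCCCCC(=O)N(c2cccc(C(=O)O)c2)c2cccc(C(=O)O)c2)c1` have both been tested in an assay on isolated protein for binding affinity to P-selectin (Homo sapiens), read by ELISA, tested at 500 uM; on this read-out higher numbers stand for more inhibition at the one concentration tested (going by the name of the read-out) and lower numbers for less inhibition. Compound 1 gives 12%, and compound 2 gives 20%. These two numbers lie within the usual scatter of each other, so the data do not set one compound apart from the other.

Compound 3 `CCCCCCCCCCOc1cc(OCCCCCCCCCC)cc(OCCCCCC(=O)N(c2ccc(C(=O)O)cc2)c2cccc(C(=O)O)c2)c1` has not yet been measured. It differs from compound 2 in one place: 4-carboxyphenyl in place of 3-carboxyphenyl on an amide-type nitrogen. Among the compounds with values here, no measured pair shows what such a change does here, so no shift beyond the scatter is expected in no change at the digits printed from compound 2 to compound 3 (within the scatter). Compound 3 is expected to give about 20% in this assay, somewhere from 8% to 32%.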

Compound 3, a percentage reported as inhibition, at one concentration (the size of the read-out at that concentration, not a potency): 58%
Compound 3: the middle estimate sits 38 percentage points below what was measured; measured number above the stated range.
By their numbers in this assay, from the lowest: compounds 1 and 2 (each within the scatter of the next); then compound 3.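

Swapping 3-carboxyphenyl for 4-carboxyphenyl on an amide-type nitrogen gives a number 38 percentage points higher from compound 2 to compound 3 (beyond the scatter) in this assay. The two compounds have the same atoms, joined differently, so this place on the shared core responds to where the carboxylic acid sits on its ring, something the earlier pair could not show. Nothing measured here explains the gain. On these data alone, it remains open whether replacing the other 3-carboxyphenyl in the same way would add to the gain, and whether an amine in place of the carboxylic acid would keep it.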